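The source may report more compounds than this note shows. Statements on the series, on what has been measured and on what is new or still open speak of the compounds shown alone.

Working notes on the series. Compound 1 `C[C@@H](Nc1nccc(Cl)c1NC(=O)CC#N)c1ccc(-c2cccc(F)c2C#N)cc1` carries the shared core with a 2-cyano-3-fluorophenyl group on the terminal aromatic ring; in an in vivo ADME assay on the whole organism for pharmacokinetics, with Canis familiaris (Canis lupus familiaris) as the target, at a dose of 1 mg/kg by the intravenous route (a lower number here means slower removal, a higher number faster removal of the compound), compound 1 stands at "not determined" (no result reported), so no number was reported for it. Among the compounds with values here, the only number in this assay comes from compound 2 `Cc1noc(-c2c(F)cccc2-c2ccc([C@@H](C)Nc3nccc(Cl)c3NC(=O)CC#N)cc2)n1`, which differs from compound 1 at that same terminal position; in this assay compound 2 gives 7.3 mL/min/kg. Compound 3 `COC(=O)c1c(Cl)cccc1-c1ccc([C@@H](C)Nc2nccc(Cl)c2NC(=O)CC#N)cc1` is the next member to be measured in this assay and is derived from compound 1 by the change (3-chloro-2-(methoxycarbonyl)phenyl in place of 2-cyano-3-fluorophenyl on an aromatic carbon). Within the data shown here, because compound 1 itself has no value in this assay, no step between measured compounds is available for this change, and the size and direction of its effect on clearance cannot be read from the series; the only anchor is the value of compound 2, which is a different substitution at the same position. Taking that anchor as the working reference and allowing for the usual scatter plus the uncertainty of an unrelated terminal group, compound 3 is expected to give about 10 mL/min/kg in this assay, within a range of 4 mL/min/kg to 25 mL/min/kg.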

Compound 3, clearance: 8.7 mL/min/kg
Estimate against measurement, compound 3: 1.1-fold (0.06 log units) above; the measured number falls inside the stated range.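

Within the data shown here, no step from compound 1 to compound 3 can be read in this assay: compound 1 has no single number there. The compounds shown leave open how replacing 2-cyano-3-fluorophenyl with 3-chloro-2-(methoxycarbonyl)phenyl affects clearance. No further data bearing on this result are available.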